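The source may hold more compounds than are shown below. What is called first, only, known or untested is meant among the compounds shown, and "the series" means these compounds.

Three compounds have numbers in a functional assay on A2780 cells (Homo sapiens) for antiproliferative activity, read by CellTiter-Glo, with a stated time of 72 h; a lower number here means a stronger inhibitor, a higher number a weaker inhibitor. Compound 1 (`C[C@H](NC(=O)[C@@H]1CCCN1C)c1ccc(NC(=O)N2CC(c3cccnc3)C2)cc1`) gives 5.7 nM, compound 2 (`C[C@@H](c1ccc(NC(=O)N2CC(c3cncc(N)c3)C2)cc1)N1Cc2ccccc2C1=O`) gives 45 nM, and compound 3 (`C[C@H](NC(=O)c1ncccn1)c1ccc(NC(=O)N2CC(c3cncc(N)c3)C2)cc1`) gives 340 nM. That last number is the highest of the three, and its gaps to both others lie beyond the scatter. Compound 4 (`C[C@H](NC(=O)[C@@H]1CCCN1C)c1ccc(NC(=O)N2CC(c3cncc(N)c3)C2)cc1`) has no number yet. It differs from compound 3 by a single change, (1-methylpyrrolidin-2-yl in place of pyrimidin-2-yl on a carbonyl carbon), which puts 1-methylpyrrolidin-2-yl in place of pyrimidin-2-yl on a carbonyl carbon.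

Among the measured compounds shown here, one measured step touches this part of compound 3: a 7.6-fold higher number from compound 2 to compound 3 (0.88 log units; beyond the scatter), a modest step beyond the scatter. It shows that the number responds when this part of the molecule is exchanged, although it involves a different incoming group. The closer evidence is indirect. For the measured compounds named here, compound 1 already carries the (1-methylpyrrolidin-2-yl)carbonyl group and stands at 5.7 nM, but its core differs elsewhere, and no measured step isolates that group alone. A clear move towards a lower number in this assay is therefore expected, probably larger than the measured step. The expected change is a 17-fold lower number from compound 3 to compound 4 (1.23 log units; beyond the scatter). Compound 4 is estimated at 20 nM, with an expected range of 5 nM to 80 nM.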

Compound 4, half-maximal inhibitory concentration: 34 nM
For compound 4 the middle estimate is 1.7-fold (0.23 log units) below the measured one; low and high end bracket the measured number.
By their numbers in this assay, from the lowest: compound 1; then compounds 4 and 2 (each within the scatter of the next); then compound 3.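

In this assay, among the compounds shown here, the step of a 10-fold lower number from compound 3 to compound 4 (1.00 log units; beyond the scatter) is the first measure of 1-methylpyrrolidin-2-yl in place of pyrimidin-2-yl on a carbonyl carbon with the rest of the molecule held constant, and it shows that this exchange alone moves the number well beyond the scatter. The step of a 6.0-fold higher number from compound 1 to compound 4 (0.78 log units; beyond the scatter) then shows that the ((1-methylpyrrolidin-2-yl)carbonyl)amino group does not by itself set the low number of compound 1, since amino in place of hydrogen on an aromatic carbon also shifts the result with that group unchanged. The step of a 1.3-fold lower number from compound 2 to compound 4 (0.12 log units; within the scatter) shows that the group carried by compound 4 and the larger group carried by compound 2 cannot be told apart in this assay, so the advantage over compound 3 is not unique to 1-methylpyrrolidin-2-yl.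

No measured evidence accounts for any of these steps. The compounds shown leave open how a piperidin-2-yl ring or an open dimethylaminomethyl chain on the same carbonyl carbon would compare, and how the opposite configuration of 1-methylpyrrolidin-2-yl would read.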